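Iodo in place of furan-3-yl: working notes

The source may hold more compounds than are shown below. What is called first, only, known or untested is meant among the compounds shown, and "the series" means these compounds.

Measured in a functional assay on HCT-116 cells (Homo sapiens), read by MTT assay, with a stated time of 72 h; on this read-out higher numbers stand for weaker inhibition and lower numbers for stronger inhibition:
- compound 1 `C#Cc1cn([C@@H]2O[C@H](CO)[C@@H](O)[C@H]2O)c2ncnc(OC)c12`: 4060 nM
- compound 2 `CSc1ncnc2c1c(-c1ccsc1)cn2[C@@H]1O[C@H](CO)[C@@H](O)[C@H]1O`: > 20000 nM
- compound 3 `Cc1nc(N)c2c(-c3ccoc3)cn([C@@H]3O[C@H](CO)[C@@H](O)[C@H]3O)c2n1`: > 20000 nM

Compound 3 is known only by a limit, and it stands at the limit of > 20000 nM in this assay, at which 2 of the 3 values shown sit. The value of compound 2 is a limit as well. Within the data shown here, only compound 1 has a numerical value so far.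

Compound 4 `Cc1nc(N)c2c(I)cn([C@@H]3O[C@H](CO)[C@@H](O)[C@H]3O)c2n1` carries iodo in place of furan-3-yl on an aromatic carbon of a five-membered aromatic ring with 1 nitrogen: iodo in place of furan-3-yl on an aromatic carbon. Among the measured compounds shown here, no measured compound pair isolates this change, so any expectation rests on thin ground. Compounds 2 and 3 both carry a five-membered aromatic ring on that carbon. Compound 1 has no such ring there and gives 4060 nM, although it also differs from compound 3 elsewhere on the shared core. On that slender basis, a move towards stronger inhibition in this assay is expected, of moderate size rather than a dramatic one. The estimated change is an at least 2.8-fold lower number from compound 3 to compound 4 (0.45 log units; beyond the scatter). A further limit remains a real possibility for compound 4. The expected value for compound 4 is 7000 nM, with an estimated range from 800 nM to 20000 nM.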

Compound 4, half-maximal inhibitory concentration: > 20000 nM
Compound 4: a limit, no number; the forecaster's own chance of this, stated with the estimate: 40%; middle value at least 2.8-fold (0.45 log units) from the limit.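

Compound 3 and compound 4 are both known only as limits in this assay, so the change from furan-3-yl to iodo cannot be read as a step: the limit of > 20000 nM in this assay, at which 3 of the 4 values shown sit.

The compounds shown leave open whether iodo in place of furan-3-yl on that aromatic carbon changes inhibition at all, and in which direction.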